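A few compounds are considered here, and "the series" means these few. Any claim that something is new, unique, unknown or untested is made for them only; others in the source may bear on it.

Three compounds share one core and are compared in a functional assay on A549 cells (Homo sapiens) for antiproliferative activity, read by MTT assay, with a stated time of 72 h; a higher number here means a weaker inhibitor, a lower number a stronger inhibitor. Compound 1, with the structure `O=C(Nc1ccc(Oc2ccnc3[nH]ccc23)cc1)c1cc2cccnc2n(-c2ccc(Br)cc2F)c1=O`, gives 1570 nM in this assay. Compound 2, `O=C(Nc1ccc(Oc2ccnc3[nH]ccc23)c(F)c1)c1cc2cccnc2n(-c2ccc(F)c(Cl)c2)c1=O`, gives 630 nM. Compound 3, `Cn1ccc2c(Oc3ccc(NC(=O)c4cc5cccnc5n(-c5ccccc5)c4=O)cc3)ccnc21`, gives 850 nM, which places it second highest of the three numbers; its nearest neighbour is compound 2 and its furthest is compound 1, and both of those gaps lie within the scatter of repeated measurements, so the three values cannot be told apart with confidence.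

Compound 4, `Cn1ccc2c(Oc3ccc(NC(=O)c4cc5cccnc5n(-c5ccc(C(F)(F)F)cc5Cl)c4=O)cc3)ccnc21`, has not yet been measured. It differs from compound 3 in one place: 2-chloro-4-(trifluoromethyl)phenyl in place of phenyl on an aromatic nitrogen, in words a 2-chloro-4-(trifluoromethyl)phenyl in place of phenyl on an aromatic nitrogen. Among the compounds with values here, no directly comparable pair exists in this set, since compound 1 and compound 2 each carry a substituted phenyl at that position but also differ elsewhere from compound 3. The account therefore expects, on this basis alone, a step of a 1.7-fold lower number from compound 3 to compound 4 (0.23 log units; within the scatter) that stays within or only just beyond the scatter, leaning toward a lower number. The estimate for compound 4 in this assay is 500 nM, with a range from 150 nM to 1800 nM.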

Compound 4, half-maximal inhibitory concentration: 8250 nM
Estimate against measurement, compound 4: 17-fold (1.22 log units) below; the measured number lies above the stated range.
By their numbers in this assay, from the lowest: compounds 2, 3 and 1 (each within the scatter of the next, the first and the last beyond it); then compound 4.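

In this assay, the group on the aromatic nitrogen proves able to move the number well beyond the scatter: 2-chloro-4-(trifluoromethyl)phenyl in place of phenyl gives a 9.7-fold higher number from compound 3 to compound 4 (0.99 log units; beyond the scatter). Within the data shown here, this is the first step in the set that can be read as a single change, as the earlier compounds offered no pair differing in one place, and it shows that the number at this position can rise sharply even though the entering group, like phenyl, has no hydrogen-bond donors, no hydrogen-bond acceptors and no net charge. No measurement of any property of these compounds accompanies the result, so nothing here accounts for the step.

The chloro and the trifluoromethyl enter together, so the compounds shown cannot say whether one of them alone carries the step or whether it takes both. They also leave open how a phenyl bearing a different kind of group, such as an amine or a carboxylic acid, would read in this assay.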